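Methoxy removal on the aryl ring of the triazole series

This account rests on a few compounds, and the source may have more. Where it says the series, first, only, none or still open, it means among the compounds named here.

Three compounds carry readings in a functional assay on the whole organism (strain albino) for inhibition, with Rattus norvegicus as the target, read by paw edema, with a stated time of 5 h, at a dose of 0.28 mmol/kg by the oral route; on this read-out higher numbers stand for more inhibition at the one dose given (going by the name of the read-out) and lower numbers for less inhibition. Compound 1 `C=CCn1c(SCC(=O)c2ccccc2)nnc1-c1ccccc1` gives 66%, compound 2 `C=CCn1c(SC/C(=N\O)c2ccccc2)nnc1-c1ccc(OC)c(OC)c1` gives 69%, and compound 3 `CCn1c(SCC(=O)c2ccccc2)nnc1-c1ccc(OC)cc1` gives 61%. The three numbers lie within the usual scatter of one another, so compound 3 is not set apart from either of the other two in this assay. Compound 4 `CCn1c(SCC(=O)c2ccccc2)nnc1-c1ccccc1` is not yet measured; it differs from compound 3 in one place: hydrogen in place of methoxy on an aromatic carbon. Among the measured compounds shown here, no step between measured pairs that differ in one place is available to gauge this change, so no shift beyond the scatter is expected in either direction. The estimated step from compound 3 to compound 4 in this assay is a number 3 percentage points higher from compound 3 to compound 4 (within the scatter). Compound 4 is therefore expected to give about 64%, within a range from 50% to 76%.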

Compound 4, a percentage reported as inhibition, in the whole organism at one dose (the size of the read-out at that dose, not a potency): 51%
Compound 4: the middle estimate sits 13 percentage points above what was measured, and the stated range covers the measured number.
By their numbers in this assay, from the lowest: compounds 4, 3, 1 and 2 (each within the scatter of the next, the first and the last beyond it).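

In this assay, among the compounds shown here, hydrogen in place of methoxy on the aromatic carbon gives a number 10 percentage points lower from compound 3 to compound 4 (within the scatter) and so, as the first direct reading of this change, stays inside the noise of the assay. Methyl in place of vinyl on the chain carbon gives a number 15 percentage points lower from compound 1 to compound 4 (beyond the scatter) and is the first one-place change in the series to clear the scatter, though only modestly. Nothing measured bears on the reason for either step.

From the compounds shown here alone, whether an amine or a chlorine atom at this place would read differently from methoxy stays open. So does whether a longer chain such as propyl on the aromatic nitrogen would follow the step seen with methyl and vinyl.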